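The source may hold more compounds than are shown below. What is called first, only, known or untested is meant among the compounds shown, and "the series" means these compounds.

Measured so far: compound 1 `CCCC/C(=C\C=C\C(=O)N[C@H](C)CCCc1cccnc1)c1ccc(OC)cc1` gives 14 nM in an assay (Canis lupus familiaris) for binding affinity to platelet-activating factor receptor (Homo sapiens), read by radioligand binding; on this read-out higher numbers stand for weaker inhibition and lower numbers for stronger inhibition; compound 2 `CC[C@H](CCCc1cccnc1)NC(=O)/C=C/C=C(c1ccc(OC)cc1)c1ccc(OC)cc1` gives 120 nM; compound 3 `COc1ccc(C(=C/C=C/C(=O)NCCCCc2cccnc2)c2ccc(OC)cc2)cc1` gives 25 nM.

Compound 1 holds the lowest of the three numbers in this assay; its gap to compound 3 is within the scatter, its gap to compound 2 is beyond it. Compound 4 `CCC/C(=C\C=C\C(=O)N[C@H](C)CCCc1cccnc1)c1ccc(OC)cc1` differs from compound 1 by hydrogen in place of methyl on a saturated chain carbon, three bonds along the chain from a double-bonded chain carbon. Going by the values given here, no measured step alters this chain. Among the compounds with values here, the only measured step, a 4.8-fold lower number from compound 2 to compound 3 (0.68 log units; beyond the scatter), concerns a group on the carbon bound to the amide nitrogen, a different place, and so does not bear directly on the change here. With no guidance from the series, the step of a 1.4-fold higher number from compound 1 to compound 4 (0.15 log units; within the scatter) is expected to stay within the scatter. Compound 4 is therefore estimated at 20 nM, between 7 nM and 60 nM.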

Compound 4, half-maximal inhibitory concentration: 50 nM
For compound 4 the middle estimate is 2.5-fold (0.40 log units) below the measured one; the range from low to high includes it.
By their numbers in this assay, from the lowest: compounds 1, 3 and 4 (each within the scatter of the next, the first and the last beyond it); then compound 2.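

Going by these compounds alone, this is the first measured change on the chain of the core: going from butyl to propyl gives a 3.6-fold higher number from compound 1 to compound 4 (0.55 log units; beyond the scatter) in this assay. The step lies beyond the scatter, so the binding read-out responds to the loss of a single methyl at this position, with the butyl compound giving the lower number. No available data give a cause for this step.

Going by these compounds, whether a longer chain such as pentyl would lower the number further remains open. So does whether an ethyl chain would raise it again, or whether a terminal amine would be accepted here.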